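Hydroxyphenyl for Methoxyphenyl on a Shared Lactone Core

A few compounds are considered here, and "the series" means these few. Any claim that something is new, unique, unknown or untested is made for them only; others in the source may bear on it.

Of the compounds shown here, three built on one shared core have been tested in a functional assay on HepG2 cells (Homo sapiens) for antiproliferative activity, read by MTT assay, with a stated time of 72 h; a lower number here means a stronger inhibitor, a higher number a weaker inhibitor. Compound 1 `COc1ccc(-c2cn(C/C=C3\OC(=O)C(OCc4ccccc4)=C3OCc3ccccc3)nn2)cc1` gives only a limit of this assay, > 100000 nM, so it stands at the weak end of the set without a number of its own. Compound 2 `O=C1O[C@H]([C@@H](O)Cn2cc(-c3cccc(O)c3)nn2)C(OCc2ccccc2)=C1OCc1ccccc1` gives 62700 nM in this assay. Compound 3 `COc1ccc(-c2cn(C[C@H](O)[C@H]3OC(=O)C(OCc4ccccc4)=C3OCc3ccccc3)nn2)cc1` gives 46400 nM in this assay. Among the compounds with values here, the single step between measured compounds that differ in one place, a 1.4-fold lower number from compound 2 to compound 3 (0.13 log units; within the scatter), is the same exchange of aryl groups as the one under study here, run in the opposite direction and on a core that differs from the one of compound 1.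

Compound 4 `O=C1O/C(=C\Cn2cc(-c3cccc(O)c3)nn2)C(OCc2ccccc2)=C1OCc1ccccc1` has not yet been measured in this assay. It differs from compound 1 by 3-hydroxyphenyl in place of 4-methoxyphenyl on an aromatic carbon. Within the data shown here, the only relevant precedent, compound 2 to compound 3, bears directly on this exchange, and because a 1.4-fold lower number from compound 2 to compound 3 (0.13 log units; within the scatter) lay within the scatter, no shift beyond the scatter is expected in this assay from the change. Compound 4 is therefore expected to give about 120000 nM in this assay, with a range from 50000 nM to 300000 nM, the step that the limit leaves unreadable from compound 1 to compound 4 being an estimate that most likely ends again in a limit rather than a number.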

Compound 4, half-maximal inhibitory concentration: 61700 nM
Estimate against measurement, compound 4: 1.9-fold (0.29 log units) above, within the range that was stated.
By their numbers in this assay, from the lowest: compounds 3, 4 and 2 (each within the scatter of the next). At a limit, above all of these: compound 1.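

The exchange now has a reading on a second core: in this assay, 3-hydroxyphenyl in place of 4-methoxyphenyl on the aromatic carbon of the five-membered ring gives an at least 1.6-fold lower number from compound 1 to compound 4 (0.20 log units; that floor lies within the scatter). That figure is a floor and not a full size, and the two cores can now be set side by side, though without a settled comparison: the same change on two cores in this assay, a 1.4-fold lower number (0.13 log units; within the scatter) from compound 2 to compound 3 and an at least 1.6-fold higher number (0.20 log units; that floor lies within the scatter) from compound 4 to compound 1; the limit leaves it open whether they differ. Compound 1 stays at a limit, the only one in the set, and its true value is unknown: the limit of > 100000 nM in this assay, at which 1 of the 4 values shown sits.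

The exchange alters both the group on the phenyl ring and where that group sits, and the compounds shown do not separate the two, which 3-methoxyphenyl and 4-hydroxyphenyl on this core could do. They also leave open how 3-aminophenyl at the same carbon would read in this assay, and whether the full size of the step on this core matches the one on the other core.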